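Trading a 4-ethylphenyl substituent for a hydroxymethyl group

This account rests on a few compounds, and the source may have more. Where it says the series, first, only, none or still open, it means among the compounds named here.

Compound 1 `CCc1ccc(-c2ccc(NC3=CC(=O)c4ncncc4C3=O)cc2)cc1` is measured in a functional assay on PANC-1 cells (Homo sapiens) for cytotoxicity, read by MTT assay, with a stated time of 72 h (on this read-out higher numbers stand for weaker inhibition and lower numbers for stronger inhibition), where compound 1 gives 1200 nM, the highest of the three numbers shown, although the other two lie within the scatter of it. Compound 2 `COc1cccc(NC2=CC(=O)c3ncncc3C2=O)c1` gives 600 nM in this assay, and compound 3 `O=C1C(NCc2ccc(F)cc2)=CC(=O)c2ncncc21` gives 1000 nM. Compound 4 `O=C1C(Nc2ccc(CO)cc2)=CC(=O)c2ncncc21` awaits measurement. It differs from compound 1 by hydroxymethyl in place of 4-ethylphenyl on an aromatic carbon. Going by the values given here, no measured pair isolates this change, so its step size is unknown. For compound 4 the expected step of a 1.3-fold higher number from compound 1 to compound 4 (0.10 log units; within the scatter) is none beyond the scatter, with at most a slight drift toward weaker inhibition. Compound 4 is therefore estimated at 1500 nM, within a range from 500 nM to 4500 nM.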

Compound 4, half-maximal inhibitory concentration: 1000 nM
Compound 4: the middle estimate sits 1.5-fold (0.18 log units) above what was measured; the measured number falls inside the stated range.
By their numbers in this assay, from the lowest: compounds 2, 3, 4 and 1 (each within the scatter of the next).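

Hydroxymethyl in place of 4-ethylphenyl on an aromatic carbon gives, in this assay, a 1.2-fold lower number from compound 1 to compound 4 (0.08 log units; within the scatter) and is the first step measured at this position. Across this step, a six-membered aromatic ring of carbon only leaves and a hydrogen-bond donor and acceptor enter, yet the number stays within the scatter. No supporting measurement accounts for this result.

The compounds shown leave open whether an amine or a carboxylic acid at this position would also stay within the scatter. They also leave open how a longer chain, such as hydroxyethyl, would compare.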